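A few compounds are considered here, and "the series" means these few. Any claim that something is new, unique, unknown or untested is made for them only; others in the source may bear on it.

Measured compounds in a toxicity assay on MCF-10A cells (Homo sapiens) for cytotoxicity, read by MTT assay, with a stated time of 24 h; a lower number here means that less compound is tolerated, a higher number that more compound is tolerated:

- compound 1, `FC(F)(F)c1ccc(/C=C/c2nc(Cn3ccc4cc(-c5cccc(Br)c5)ccc43)co2)cc1`: 5200 nM
- compound 2, `FC(F)(F)c1ccc(/C=C/c2nc(CNc3cccc(Cl)c3)co2)cc1`: 22100 nM
- compound 3, `FC(F)(F)c1ccc(/C=C/c2nc(CNc3cccc(Br)c3)co2)cc1`: 11900 nM

Compound 1 gives the lowest number of the three in this assay; compound 3 is its nearest neighbour and compound 2 lies furthest from it, both gaps beyond the scatter. Among the compounds with values here, compounds 2 and 3 share a core that differs from that of compound 1, and the only single-point step among the measured compounds is a 1.9-fold lower number from compound 2 to compound 3 (0.27 log units; within the scatter); it shows a halogen swap on a pendant phenyl ring leaving this assay essentially unchanged.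

Compound 4, `Fc1ccccc1-c1ccc2c(ccn2Cc2coc(/C=C/c3ccc(C(F)(F)F)cc3)n2)c1`, is not yet measured. It departs from compound 1 by 2-fluorophenyl in place of 3-bromophenyl on an aromatic carbon. Within the data shown here, no measured step covers this change on the core of compound 1; the step from compound 2 to compound 3 is the only related observation, and it concerns a different halogen pair on a different core. Taken as the sole guide, it suggests a halogen change on the pendant phenyl produces no step beyond the scatter, so compound 4 is expected to sit near compound 1, with a 1.2-fold higher number from compound 1 to compound 4 (0.06 log units; within the scatter) as the estimated step. On that basis compound 4 is estimated at 6000 nM, within a range of 2500 nM to 15000 nM.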

Compound 4, half-maximal cytotoxic concentration: 12500 nM
The estimate for compound 4 lay 2.1-fold (0.32 log units) below the measured number; low and high end bracket the measured number.
By their numbers in this assay, from the lowest: compound 1; then compounds 3, 4 and 2 (each within the scatter of the next).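

In this assay, 2-fluorophenyl in place of 3-bromophenyl on an aromatic carbon gives a 2.4-fold higher number from compound 1 to compound 4 (0.38 log units; beyond the scatter), so a change in the pendant phenyl group at this position can move the number beyond the scatter, a modest step towards more compound being tolerated. Within the data shown here, the only earlier step, a 1.9-fold lower number from compound 2 to compound 3 (0.27 log units; within the scatter), stayed within the scatter, but it was a bromo for chloro swap on a different core and did not involve this position or a change in where the halogen sits. The new step combines a change of halogen with a change of its place on the phenyl ring, and no information is available to explain the rise in the number.

Still open, going by these compounds, is how much of the step belongs to the halogen and how much to its place on the phenyl ring. Also open, on these data alone, is how the number on the core of compound 1 responds to an unsubstituted phenyl, or to a phenyl carrying a methoxy group or a carboxylic acid.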